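The compounds below may be only part of what the source reports. "The series", "measured", "known", "first", "only" and "open" are said of these compounds alone.

Measured compounds:
compound 1 `Nc1nc(Cl)c2ncn(Cc3ccccc3CCl)c2n1` — 27500 nM
compound 2 `Nc1nc(Cl)c2ncn(Cc3cccc(CCl)c3)c2n1` — 15100 nM

Two compounds have been run in a functional assay on SNB-19 cells (Homo sapiens) for cytotoxicity, read by sulforhodamine B assay, with a stated time of 48 h; on this read-out higher numbers stand for weaker inhibition of growth and lower numbers for stronger inhibition of growth. Compound 1 and compound 2 share the same core and differ only in where the chloromethyl-bearing benzyl group is substituted; their values sit within the scatter of one another, so neither can be ranked against the other, and both sit at weak growth inhibition.

Compound 3 `ClCc1ccccc1Cn1cnc2c(Cl)ncnc21` has not been measured. It differs from compound 1 by hydrogen in place of amino on an aromatic carbon. Within the data shown here, no measured pair reports this change, so nothing shows how the amino group contributes. Both measured values are weak, and the expectation is that compound 3 in this assay will stay near that level, with no step beyond the scatter in either direction the more likely outcome. Compound 3 is accordingly estimated at 32000 nM, with a range of 9000 nM to 110000 nM, which corresponds to an expected step of a 1.2-fold higher number from compound 1 to compound 3 (0.07 log units; within the scatter).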

Compound 3, concentration for total growth inhibition: > 100000 nM
Compound 3 was reported as a limit; the forecaster's own chance of this, stated with the estimate: 15%; middle value at least 3.1-fold (0.49 log units) away from the limit.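

Hydrogen in place of amino, on the aromatic carbon between two ring nitrogen atoms, gives in this assay an at least 3.6-fold higher number from compound 1 to compound 3 (0.56 log units; beyond the scatter), the first step in the series to lie beyond the scatter and the first reading of this position. Compound 3 gives > 100000 nM, which is a limit of the assay and not a number. The step is therefore a bound and not a size: the limit of > 100000 nM in this assay, at which 1 of the 3 values shown sits.

On these data alone, whether other groups on this carbon, such as methylamino, hydroxyl or methyl, would stay with amino or with hydrogen remains open. Also open, as far as these compounds go, is whether the same change would give a like step with the chloromethyl group placed as in compound 2.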